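The source may hold more compounds than are shown below. What is called first, only, known or untested is meant among the compounds shown, and "the series" means these compounds.

Measured compounds:
Compound 1 `Cc1cc(=O)oc2cc(OCc3cn(-c4ccc(F)cc4)nn3)ccc12` gives in an ADME assay on Huh-7 cells (Homo sapiens) for cytotoxicity, read by MTT assay, with a stated time of 72 h; on this read-out lower numbers stand for higher toxicity in this test and higher numbers for lower toxicity in this test > 100 ug/mL, a limit of the assay.
Compound 2 `Cc1cc(=O)oc2cc(OCc3cn(-c4ccccc4Cl)nn3)ccc12` gives > 100 ug/mL, likewise a limit.
Compound 3 `Cc1cc(=O)oc2cc(OCc3cn(-c4ccc(F)cc4F)nn3)ccc12` gives > 100 ug/mL, likewise a limit.

Compound 1 therefore stands only at a limit, and the two further values shown are limits as well, as the limit of > 100 ug/mL in this assay, at which 3 of the 3 values shown sit, records. Compound 4 `Cc1cc(=O)oc2cc(OCc3cn(-c4ccc(OC(F)(F)F)cc4)nn3)ccc12` differs from compound 1 by trifluoromethoxy in place of fluoro on an aromatic carbon. Among the measured compounds shown here, no measured step bears directly on that change; the steps a step that the two limits leave unreadable from compound 1 to compound 2, a step that the two limits leave unreadable from compound 1 to compound 3 and a step that the two limits leave unreadable from compound 2 to compound 3 all lie between limits, so neither size nor direction can be read from them. With every value shown at the limit, compound 4 is expected to sit there too, the estimated step of a number no higher from compound 1 to compound 4 (the limit leaves the size open) staying within the scatter. For compound 4 the estimate is 100 ug/mL, with a range from 50 ug/mL to 200 ug/mL.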

Compound 4, half-maximal cytotoxic concentration: > 100 ug/mL
Compound 4 was reported as a limit; the forecaster's own chance of this, stated with the estimate: 85%; the middle value sits exactly at the limit.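

No new step can be read between compound 1 and compound 4: both values are limits, and neither size nor direction shows. The compounds shown leave open how far any of them lies past the limit: the limit of > 100 ug/mL in this assay, at which 4 of the 4 values shown sit.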